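Methoxy to hydroxy at compound 4: an expectation

The source may report more compounds than this note shows. Statements on the series, on what has been measured and on what is new or still open speak of the compounds shown alone.

- compound 1 `COc1ccc(/C=C/C(=O)c2ccccc2-c2ccc(F)cc2)cc1O`: 87 nM
- compound 2 `COc1ccc(/C=C/C(=O)c2ccccc2-c2cccc(F)c2)cc1`: 73 nM
- compound 3 `COc1ccc(/C=C/C(=O)c2ccccc2-c2cccc(F)c2)cc1OC`: 650 nM

All three were tested in a functional assay on CNE-2 cells (Homo sapiens) for antiproliferative activity, read by sulforhodamine B assay, with a stated time of 48 h; a higher number here means a weaker inhibitor, a lower number a stronger inhibitor. Compound 3 has the highest number of the set, and its gap to each of the other two lies beyond the scatter, making it the weakest inhibitor of the three. The next analogue is compound 4 `COc1ccc(/C=C/C(=O)c2ccccc2-c2cccc(F)c2)cc1O`, which differs from compound 3 by one change: hydrogen in place of methyl on an oxygen on an aromatic ring, or methoxy to hydroxy.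

Among the compounds with values here, no measured step makes this exact change. The closest evidence is an 8.9-fold higher number from compound 2 to compound 3 (0.95 log units; beyond the scatter), where adding a methoxy in place of hydrogen on an aromatic carbon gave a modest loss in this assay. Compound 1 also bears a hydroxy group, and compound 1 gives 87 nM, although its fluoro group is placed differently from that of compound 4. Together these suggest that removing the methyl should recover much of the gap. The expected change is a 6.5-fold lower number from compound 3 to compound 4 (0.81 log units; beyond the scatter), towards a lower number and beyond the scatter. For compound 4 the estimated value is 100 nM, with an expected range from 35 nM to 320 nM.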

Compound 4, half-maximal inhibitory concentration: 17 nM
Beside the measured number, compound 4's estimate is 5.9-fold (0.77 log units) above it; the whole stated range lies above it.
By their numbers in this assay, from the lowest: compound 4; then compounds 2 and 1 (each within the scatter of the next); then compound 3.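

Hydrogen in place of methyl on an oxygen on an aromatic ring gave a 38-fold lower number from compound 3 to compound 4 (1.58 log units; beyond the scatter) in this assay and made compound 4 the strongest inhibitor of the four, so the methyl on this oxygen carries a large part of the difference in this series. The earlier compounds shown here showed only a loss on adding methoxy at this carbon, whereas hydroxy in place of hydrogen gave a 4.3-fold lower number from compound 2 to compound 4 (0.63 log units; beyond the scatter) and thus moved the number the opposite way from methoxy. The fluoro placement also proved to matter when this hydroxy is present, as 3-fluorophenyl in place of 4-fluorophenyl gave a 5.1-fold lower number from compound 1 to compound 4 (0.71 log units; beyond the scatter) in the same assay.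

The compounds shown leave open whether an amine or an ethoxy group at this carbon would follow the hydroxy or the methoxy, and whether moving the fluoro would matter equally without the hydroxy. Nothing shown here accounts for the size of these steps.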